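Trifluoromethyl in Place of Methyl: Expecting Compound 3

This account rests on a few compounds, and the source may have more. Where it says the series, first, only, none or still open, it means among the compounds named here.

Of the compounds shown here, two have been measured in an assay on isolated protein for binding affinity to corticotropin-releasing factor receptor 1 (Homo sapiens); a lower number here means a stronger inhibitor, a higher number a weaker inhibitor. Compound 1 `CCCN(CC1CC1)c1nc(C)nc(N(CC)c2ccc(N(C)C)cc2C(F)(F)F)n1` gives 5 nM. Compound 2 `CCCN(CCC)c1nc(C)nc(N(CC)c2ccc(N(C)C)cc2C)n1` gives 7 nM, the larger of the two numbers, though its gap to compound 1 lies within the usual scatter, so neither can be called stronger. Compound 3 `CCCN(CCC)c1nc(C)nc(N(CC)c2ccc(N(C)C)cc2C(F)(F)F)n1` differs from compound 2 by trifluoromethyl in place of methyl on an aromatic carbon. Within the data shown here, no measured pair isolates this change, so the expectation is only that the step from compound 2 to compound 3 stays small, a 1.4-fold lower number from compound 2 to compound 3 (0.15 log units; within the scatter), with no direction secured beyond the scatter. Compound 3 is therefore expected to give about 5 nM, between 2 nM and 12 nM.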

Compound 3, inhibition constant: 6 nM
For compound 3 the middle estimate is 1.2-fold (0.08 log units) below the measured one; measured number inside the range.
By their numbers in this assay, from the lowest: compounds 1, 3 and 2 (each within the scatter of the next).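

In this assay trifluoromethyl in place of methyl on this aromatic carbon, ortho to a large group, gives a 1.2-fold lower number from compound 2 to compound 3 (0.07 log units; within the scatter) and so brings no change that can be told from noise, even with more heavy atoms entering. Ethyl in place of cyclopropyl on the saturated chain carbon gives a 1.2-fold higher number from compound 1 to compound 3 (0.08 log units; within the scatter) and so also leaves the number level within the scatter. Nothing available explains why either swap leaves the number level.

Going by these compounds, whether chlorine, a methoxy group or an amine on that aromatic carbon would also keep the number level remains open. So does the effect of a longer chain on the nitrogen.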